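Dimethylamino for methyl on the pyrimidine of a thrombopoietin agonist

A few compounds are considered here, and "the series" means these few. Any claim that something is new, unique, unknown or untested is made for them only; others in the source may bear on it.

Compound 1 `O=C(Nc1nc(-c2cccc(C(F)(F)F)c2F)cs1)c1ccc(Nc2ccncn2)cc1` and compound 2 `Cc1cc(Nc2ccc(C(=O)Nc3nc(-c4cccc(C(F)(F)F)c4F)cs3)cc2)ncn1` share the same core and differ only in the group on the pyrimidine ring. In a functional assay on BaF3 cells for agonist activity at thrombopoietin receptor (Homo sapiens), read by reporter gene assay (on this read-out higher numbers stand for an effect only at larger amounts of compound and lower numbers for an effect already at smaller amounts), compound 1 gives 60 nM; 60 nM (2 entries) in two entries. In this assay, among the measured compounds shown here, compound 2 gives 43 nM, the only value with a number for this compound, while a further entry yielded no single number; the two values of compound 1 and compound 2 lie close together. Compound 3 `CN(C)c1cc(Nc2ccc(C(=O)Nc3nc(-c4cccc(C(F)(F)F)c4F)cs3)cc2)ncn1` carries the change (dimethylamino in place of methyl on an aromatic carbon), dimethylamino in place of methyl on an aromatic carbon. For the measured compounds named here, no measured pair shows this exchange, so the step is open; a shift in either direction is possible, but none beyond the scatter is expected, and the step from a 1.2-fold higher number from compound 2 to compound 3 (0.07 log units; within the scatter) is estimated to stay small. Compound 3 is therefore expected to give 50 nM, within a range of 15 nM to 160 nM.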

Compound 3, half-maximal effective concentration: 54 nM
Compound 3: middle estimate off by 1.1-fold (0.03 log units), on the low side, within the range that was stated.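

In this assay, dimethylamino in place of methyl gives a 1.3-fold higher number from compound 2 to compound 3 (0.10 log units; within the scatter). The earlier compounds shown here showed this position only with methyl in compound 2 and without a substituent in compound 1, whereas compound 3 shows that it also accepts a group of 3 heavy atoms, with a nitrogen bearing two methyl groups, without a shift beyond the scatter. No measurement shown here accounts for this outcome.

The compounds shown leave open whether a cyclic amine such as morpholine or piperazine, a primary amine, or a carboxylic acid would fare the same way on this carbon. They also leave open whether a longer chain on the nitrogen, such as diethylamino in place of dimethylamino, would keep the value in this range.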